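From Hydroxy to Ethoxy on the Shared Core

The source may report more compounds than this note shows. Statements on the series, on what has been measured and on what is new or still open speak of the compounds shown alone.

In a functional assay on HepG2 cells (Homo sapiens) for cytotoxicity, read by MTT assay (on this read-out lower numbers stand for stronger inhibition and higher numbers for weaker inhibition), compound 2 `C=C1C(=O)[C@]23C[C@@]1(O)CC[C@H]2[C@@]12C=CC(=O)[C@](C)(C(=O)O1)[C@H]2[C@@H]3C(=O)OCc1ccccc1` gives 20500 nM, within the scatter of compound 1 `C=C1C(=O)[C@]23C[C@@]1(Cl)CC[C@H]2[C@@]12C=CC(=O)[C@](C)(C(=O)O1)[C@H]2[C@@H]3C(=O)OC` at 39800 nM. Compound 3 `C=C1C(=O)[C@]23C[C@@]1(I)CC[C@H]2[C@@]12C=CC(=O)[C@](C)(C(=O)O1)[C@H]2[C@@H]3C(=O)OC` gives 87000 nM, a higher number than compound 2. Compound 4 `C=C1C(=O)[C@]23C[C@@]1(OCC)CC[C@H]2[C@@]12C=CC(=O)[C@](C)(C(=O)O1)[C@H]2[C@@H]3C(=O)OCc1ccccc1` differs from compound 2 by ethyl in place of hydrogen on an oxygen on a saturated carbon. Going by the values given here, no measured step covers this change directly. The only one available, a 2.2-fold higher number from compound 1 to compound 3 (0.34 log units; beyond the scatter), puts iodo in place of chloro on a saturated ring carbon and is modest, so only a small rise is expected in this assay, probably within the scatter. The expected change is a 1.5-fold higher number from compound 2 to compound 4 (0.17 log units; within the scatter). Compound 4 is estimated at 30000 nM, with an expected range of 12000 nM to 70000 nM.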

Compound 4, half-maximal inhibitory concentration: 29600 nM
For compound 4 the middle estimate is 1.0-fold (0.01 log units) above the measured one, and the stated range covers the measured number.
By their numbers in this assay, from the lowest: compounds 2, 4 and 1 (each within the scatter of the next); then compound 3.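

In this assay, ethyl in place of hydrogen on this oxygen gives a 1.4-fold higher number from compound 2 to compound 4 (0.16 log units; within the scatter), so the two numbers cannot be told apart. Unlike the halogen step between compound 1 and compound 3, this pair tests the oxygen substituent at this position, and it shows that the hydroxy hydrogen can be replaced by ethyl without a step beyond the scatter. No evidence at hand accounts for this result. The compounds shown leave open whether a longer chain on this oxygen would also stay within the scatter. They also leave open how an amine at this position would compare.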